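This account rests on a few compounds, and the source may have more. Where it says the series, first, only, none or still open, it means among the compounds named here.

Series notes. Compound 1 `O=C1/C(=C/c2ccc(F)cc2)CCC/C1=C\c1ccccc1[N+](=O)[O-]` and compound 2 `O=C1/C(=C/c2ccc(Cl)cc2)CCC/C1=C\c1ccccc1[N+](=O)[O-]` share one core; compound 3 `O=C1/C(=C/c2ccc(F)cc2)CCC/C1=C\c1cccc([N+](=O)[O-])c1` and the unmeasured compound 4 `O=C1/C(=C/c2ccc(Cl)cc2)CCC/C1=C\c1cccc([N+](=O)[O-])c1` share another, and the difference between the two cores is not broken down here. In an ADME assay on HPLF cells (Homo sapiens) for cytotoxicity, with a stated time of 24 h (a lower number here means that less compound is tolerated, a higher number that more compound is tolerated), compound 1 gives 67000 nM and compound 3 gives 36000 nM. For compound 2 the assay reports only a limit, > 400000 nM. The change chloro in place of fluoro on an aromatic carbon gives an at least 5.9-fold higher number from compound 1 to compound 2 (0.77 log units; beyond the scatter), a figure that rests on (the limit of > 400000 nM in this assay, at which 1 of the 3 values shown sits). Compound 4 carries the same change, (chloro in place of fluoro on an aromatic carbon), on the other core. A step of comparable size is expected from compound 3 to compound 4, a 6.1-fold higher number from compound 3 to compound 4 (0.79 log units; beyond the scatter), because compound 1 showed an at least 5.9-fold higher number from compound 1 to compound 2 (0.77 log units; beyond the scatter). The estimate for compound 4 in this assay is therefore 220000 nM, between 80000 nM and 400000 nM, with a fair chance that only a limit is reported.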

Compound 4, half-maximal cytotoxic concentration: 38000 nM
Estimate against measurement, compound 4: 5.8-fold (0.76 log units) above; the whole stated range lies above it.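

In this assay, chloro in place of fluoro on an aromatic carbon gives a 1.1-fold higher number from compound 3 to compound 4 (0.02 log units; within the scatter), so the step seen on the core of compound 1 does not carry over to the core of compound 3: the same change on two cores in this assay, an at least 5.9-fold higher number (0.77 log units; beyond the scatter) from compound 1 to compound 2 and a 1.1-fold higher number (0.02 log units; within the scatter) from compound 3 to compound 4, at least 5.6-fold (0.75 log units) apart, beyond the scatter of two such steps. The step on the core of compound 1 has no exact size, as it rests on a limit reported for compound 2: the limit of > 400000 nM in this assay, at which 1 of the 4 values shown sits. This single pair of cores shows that the change cannot be assumed to transfer within the series, but it does not show what causes the difference or how the change would behave on a further core. Going by these compounds, it remains open whether bromo or methoxy at the same place would follow either core. On these data alone, it also remains open whether an amine in place of the nitro group would alter the outcome of the change.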